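The source may hold more compounds than are shown below. What is called first, only, known or untested is meant among the compounds shown, and "the series" means these compounds.

Compound 1 `O=C1CCCCC/C1=C\c1cccc(F)c1` and compound 2 `O=C1CCCCC/C1=C\c1ccc(F)cc1` carry the same atoms joined differently; the difference between the two cores is not broken down here. In a functional assay on P388 cells (Mus musculus) for inhibition (a higher number here means a weaker inhibitor, a lower number a stronger inhibitor), compound 1 gives only a limit, > 50000 nM. In this assay compound 2 likewise gives only a limit, > 50000 nM. Compound 3 `O=C1CCCCC/C1=C\c1cccc(Cl)c1` is made from compound 1 by the change (chloro in place of fluoro on an aromatic carbon), and in this assay compound 3 gives 25700 nM. The step of an at least 1.9-fold lower number from compound 1 to compound 3 (0.28 log units; that floor lies within the scatter) can be given only as a bound because compound 1 sits at the limit of > 50000 nM in this assay, at which 2 of the 3 values shown sit. Compound 4 `O=C1CCCCC/C1=C\c1ccc(Cl)cc1`, not yet measured, carries the same kind of change, (chloro in place of fluoro on an aromatic carbon), the chloro standing para rather than meta to a group of 9 heavy atoms. Compound 4 is expected to show a step of an at least 1.6-fold lower number from compound 2 to compound 4 (0.22 log units; that floor lies within the scatter) in this assay. That expectation rests on the step of an at least 1.9-fold lower number from compound 1 to compound 3 (0.28 log units; that floor lies within the scatter). In this assay compound 4 is thus estimated at 30000 nM, from 12000 nM to 80000 nM.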

Compound 4, half-maximal inhibitory concentration: 19100 nM
Compound 4: middle estimate off by 1.6-fold (0.20 log units), on the high side; measured number inside the range.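

In this assay, chloro in place of fluoro on an aromatic carbon, here para to a group of 9 heavy atoms, gives an at least 2.6-fold lower number from compound 2 to compound 4 (0.41 log units; beyond the scatter). This change therefore carries over to a second core with the same direction of step, but the size of the carried-over step is not established: the same change on two cores in this assay, an at least 1.9-fold lower number (0.28 log units; that floor lies within the scatter) from compound 1 to compound 3 and an at least 2.6-fold lower number (0.41 log units; beyond the scatter) from compound 2 to compound 4; the limit leaves it open whether they differ Neither step has an exact size, and the fluoro compounds give only limits, so the data show no more than a floor for each step: the limit of > 50000 nM in this assay, at which 2 of the 4 values shown sit.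

The compounds shown leave open whether a bromo, methyl or methoxy group in the same place would lower the number in this assay further. They also leave open how an amine or a carboxylic acid on the aromatic ring would read out there.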